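Swapping an alkyl amide for a thiazole amide

The compounds below may be only part of what the source reports. "The series", "measured", "known", "first", "only" and "open" are said of these compounds alone.

Measured in a functional assay on WI-38 VA13 cells (Homo sapiens) for cytotoxicity; on this read-out lower numbers stand for an effect already at smaller amounts and higher numbers for an effect only at larger amounts of compound:
compound 1 `N#Cc1cccc(C(=O)Nc2ccc3nc(NC(=O)C4CCCCC4)sc3c2)c1` gives 0.52 ug/mL.
compound 2 `O=C(Nc1ccc2nc(NC(=O)C3CCCCC3)sc2c1)c1ccc(Cl)cc1Cl` reaches only the limit > 4 ug/mL.
compound 3 `CCC(C)(C)C(=O)Nc1ccc2nc(NC(=O)C3CCCCC3)sc2c1` gives 1 ug/mL.

Compound 3 holds the higher of the two plain numbers, but the step of a 1.9-fold higher number from compound 1 to compound 3 (0.28 log units; within the scatter) stays within the scatter, so compound 1 and compound 3 cannot be told apart. Compound 4 `Cc1nc(C)c(C(=O)Nc2ccc3nc(NC(=O)C4CCCCC4)sc3c2)s1` differs by 2,4-dimethyl-1,3-thiazol-5-yl in place of 1,1-dimethylpropyl on a carbonyl carbon. Within the data shown here, two steps bear on this: the aromatic-to-alkyl change an at least 4.0-fold lower number from compound 2 to compound 3 (0.60 log units; beyond the scatter) was clear, whereas a 1.9-fold higher number from compound 1 to compound 3 (0.28 log units; within the scatter) was not, so carbonyl-bound aromatic rings have gone both ways in this assay. Returning to an aromatic ring is therefore expected to give no step beyond the scatter, a 1.2-fold higher number from compound 3 to compound 4 (0.08 log units; within the scatter). Compound 4 is estimated at 1.2 ug/mL, between 0.4 ug/mL and 4 ug/mL.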

Compound 4, half-maximal effective concentration: 0.39 ug/mL
Beside the measured number, compound 4's estimate is 3.1-fold (0.49 log units) above it; measured number below the stated range.
By their numbers in this assay, from the lowest: compounds 4, 1 and 3 (each within the scatter of the next, the first and the last beyond it). At a limit, above all of these: compound 2.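

An aromatic ring on this carbonyl carbon can give a lower number than 1,1-dimethylpropyl in this assay, with a 2.6-fold lower number from compound 3 to compound 4 (0.41 log units; beyond the scatter), which neither earlier ring did beyond the scatter. The choice of ring also matters, with an at least 10-fold lower number from compound 2 to compound 4 (1.01 log units; beyond the scatter), whereas a 1.3-fold lower number from compound 1 to compound 4 (0.12 log units; within the scatter) means the 3-cyanophenyl and 2,4-dimethyl-1,3-thiazol-5-yl rings cannot be told apart. The value of compound 2 is a limit, not a number: the limit of > 4 ug/mL in this assay, at which 1 of the 4 values shown sits.

Still open, from the compounds shown here alone, is how a plain phenyl ring or a ring carrying an amine would read on this carbonyl carbon. Also open, going by these compounds, is which of the two chlorines in compound 2 matters.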